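Methoxy to Fluoro on a Weakly Active Amide Series

The compounds below may be only part of what the source reports. "The series", "measured", "known", "first", "only" and "open" are said of these compounds alone.

Compound 1 `COc1ccc(-c2nc3ccccc3s2)cc1NC(=O)c1cnccc1Cl` was tested in an ADME assay on Raji cells (Homo sapiens) for inhibition, with a stated time of 72 h (on this read-out higher numbers stand for an effect only at larger amounts of compound and lower numbers for an effect already at smaller amounts), where compound 1 gives 13000 nM. Compound 2 `O=C(Nc1cc(-c2nc3ccccc3s2)ccc1F)c1cnccc1Cl` differs from compound 1 in one place: fluoro in place of methoxy on an aromatic carbon. In this assay compound 2 reaches only the limit of the assay, > 25000 nM, which is not a number. The step of an at least 1.9-fold higher number from compound 1 to compound 2 (0.28 log units; that floor lies within the scatter) is therefore known only as a floor. Compound 3 `COc1ccc(-c2nc3ccccc3o2)cc1NC(=O)c1cnccc1Cl` keeps the methoxy but carries a different core: 1,3-benzoxazol-2-yl in place of 1,3-benzothiazol-2-yl on an aromatic carbon. In this assay compound 3 likewise reaches only the limit, > 25000 nM. The step of an at least 1.9-fold higher number from compound 1 to compound 3 (0.28 log units; that floor lies within the scatter) is again known only as a floor, and the limit of > 25000 nM in this assay, at which 2 of the 3 values shown sit, marks where two of the three values sit.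

Compound 4 `O=C(Nc1cc(-c2nc3ccccc3o2)ccc1F)c1cnccc1Cl` has not yet been measured. It differs from compound 3 in one place: fluoro in place of methoxy on an aromatic carbon. This is the same kind of change as from compound 1 to compound 2, though not the same one: there the place is para to a 1,3-benzothiazol-2-yl group, here it is para to a 1,3-benzoxazol-2-yl group. The expectation rests on compound 3, which gives only the limit > 25000 nM. It also rests on the earlier step of an at least 1.9-fold higher number from compound 1 to compound 2 (0.28 log units; that floor lies within the scatter), a floor that lies within the scatter. Compound 4 is expected to show a step that the limit leaves unreadable from compound 3 to compound 4. The estimate for compound 4 in this assay is 35000 nM, expected to fall between 20000 nM and 70000 nM.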

Compound 4, half-maximal effective concentration: > 25000 nM
Compound 4: only a limit was reported; the forecaster's own chance of this, stated with the estimate: 85%; the middle value does not contradict the limit.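

In this assay compound 4 gives > 25000 nM as a limit and not a number. For the compounds shown here, compound 3 also gives only a limit, so no step from compound 3 to compound 4 can be read. The compounds shown leave open whether fluoro in place of methoxy changes the read-out at all, as only compound 1 gives a number and the others share one mark: the limit of > 25000 nM in this assay, at which 3 of the 4 values shown sit.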